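The source may report more compounds than this note shows. Statements on the series, on what has been measured and on what is new or still open speak of the compounds shown alone.

Within this set compound 1 `Cc1ccc(Nc2nc(Cl)nc3c2ncn3Cc2ccc(C(=O)Nc3ccccc3N)cc2)cc1` stands highest: in a functional assay on HepG2 cells (Homo sapiens) for antiproliferative activity, read by CCK-8 assay, with a stated time of 72 h, tested at 8 uM (on this read-out lower numbers stand for a weaker effect and higher numbers for a stronger effect at the one concentration tested), compound 1 gives 82%. Going by the values given here, compound 2 `Cc1ccc(Nc2nc(Cl)nc3c2ncn3Cc2ccc(/C=C/C(=O)Nc3ccccc3N)cc2)cc1` gives 43% in this assay, and the step of a number 39 percentage points lower from compound 1 to compound 2 (beyond the scatter) is the only one-place step measured so far. Compound 3 `CCCCn1cnc2c(NCc3ccc(C(=O)Nc4ccccc4N)cc3)nc(Cl)nc21` differs from compound 1 in more than one place; in this assay compound 3 gives 19.6%. Compound 4 `Nc1ccccc1NC(=O)c1ccc(Cn2cnc3c(Nc4ccc(-c5ccccn5)cc4)nc(Cl)nc32)cc1` is the next entry; its change from compound 1 is pyridin-2-yl in place of methyl on an aromatic carbon, which cut one bond further out reads 4-methylphenyl to 4-(pyridin-2-yl)phenyl. Among the compounds with values here, no measured step touches that position, so the data give neither size nor direction for it. The number of compound 1 leaves more room downward than upward. Compound 4 is therefore expected to give an estimated 75%, within 50% to 92%, an expected step of a number 7 percentage points lower from compound 1 to compound 4 (within the scatter).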

Compound 4, a percentage reported as inhibition, at one concentration (the size of the read-out at that concentration, not a potency): 41.2%
Compound 4: the middle estimate sits 33.8 percentage points above what was measured; the measured number lies below the stated range.
By their numbers in this assay, from the lowest: compound 3; then compounds 4 and 2 (each within the scatter of the next); then compound 1.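

In the 4-methylphenyl group of compound 1, the carbon para to a large group is now shown to be sensitive to substitution. In this assay, the change to 4-(pyridin-2-yl)phenyl gives a number 40.8 percentage points lower from compound 1 to compound 4 (beyond the scatter). This single step gives a downward direction for one large aromatic replacement only, and nothing available explains the drop.

Open, on these data alone, is whether a plain phenyl, without the ring nitrogen, would behave like pyridin-2-yl. Also open, as far as these compounds go, is whether a methoxy group or a chlorine at this carbon would keep the level of compound 1.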